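A few compounds are considered here, and "the series" means these few. Any claim that something is new, unique, unknown or untested is made for them only; others in the source may bear on it.

In an in vitro assay on CHOK cells for displacement of a labelled ligand from growth hormone secretagogue receptor type 1 (Homo sapiens) (on this read-out higher numbers stand for weaker inhibition and lower numbers for stronger inhibition), compound 3 `N#Cc1ccc(COc2ccc(-c3c(N)nc(N)nc3COCc3ccccc3)cc2)cc1` gives 83 nM, the highest number of the three measured compounds. Compound 1 `CC(=O)c1ccc(CNc2ccc(-c3c(N)nc(N)nc3COCc3ccccc3)cc2)cc1` gives 1.2 nM and compound 2 `Nc1nc(N)c(-c2ccc(NCc3csc(Cl)c3)cc2)c(COCc2ccccc2)n1` gives 6.3 nM; between those two there is a 5.3-fold higher number from compound 1 to compound 2 (0.72 log units; beyond the scatter). Compound 4 `Nc1nc(N)c(-c2ccc(CNc3ccc([N+](=O)[O-])cc3)cc2)c(COCc2ccccc2)n1` carries ((4-nitrophenyl)amino)methyl in place of (4-cyanobenzyl)oxy on an aromatic carbon. Going by the values given here, no measured step makes this exact change. Among the compounds with values here, the steps that bear on it are a 69-fold higher number from compound 1 to compound 3 (1.84 log units; beyond the scatter) and a 13-fold higher number from compound 2 to compound 3 (1.12 log units; beyond the scatter), in each of which a (4-cyanobenzyl)oxy group took the place of a group with one hydrogen-bond donor on the linking nitrogen, and each raised the number by a large amount. Compound 4 brings back one hydrogen-bond donor in the linker, though with the saturated chain carbon and the nitrogen exchanged and a (4-nitrophenyl) group in place of the nitrile-bearing ring, so the measured steps speak only partly for it. A drop in the number, smaller than the steps into compound 3, is therefore expected for compound 4, a 5.5-fold lower number from compound 3 to compound 4 (0.74 log units; beyond the scatter). In this assay compound 4 is estimated at 15 nM, ranging from 3 nM to 80 nM.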

Compound 4, half-maximal inhibitory concentration: 0.8 nM
Estimate against measurement, compound 4: 19-fold (1.27 log units) above, and the stated range ends above it.
By their numbers in this assay, from the lowest: compounds 4 and 1 (each within the scatter of the next); then compound 2; then compound 3.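

In this assay, ((4-nitrophenyl)amino)methyl in place of (4-cyanobenzyl)oxy gives the largest step in the series (a 100-fold lower number from compound 3 to compound 4 (2.02 log units; beyond the scatter)), so this position on the aromatic ring can carry a group other than (4-acetylbenzyl)amino without the loss seen in compound 3. Against that group the change stays within the scatter (a 1.5-fold lower number from compound 1 to compound 4 (0.18 log units; within the scatter)), and compound 1 and compound 4 cannot be told apart, even though the saturated chain carbon and the nitrogen stand exchanged in compound 4. Against the ((5-chlorothiophen-3-yl)methyl)amino group of compound 2, the step is modest (a 7.9-fold lower number from compound 2 to compound 4 (0.90 log units; beyond the scatter)), which shows that a nitrogen-containing linker alone does not fix the number and that the aryl group on it also counts. The compounds shown leave open whether an amide linker, or a carboxylic acid or primary amine in place of the nitro group, would keep the number this low. Nothing measured here explains the size of these steps.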